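A few compounds are considered here, and "the series" means these few. Any claim that something is new, unique, unknown or untested is made for them only; others in the source may bear on it.

Measured in a physicochemical assay for solubility, in phosphate buffer, with a stated time of 18 h, at pH 7.4; a lower number here means a less soluble compound, a higher number a more soluble compound:
- Compound 1 `COc1cc2ncnc(-n3nc(-c4ccccn4)nc3N)c2cc1[N+](=O)[O-]`: 2000 nM
- Compound 2 `COc1cc2ncnc(-n3nc(-c4ccccn4)nc3N)c2cc1N`: 3000 nM
- Compound 3 `COc1cc2ncnc(-n3nc(-c4ccccn4)nc3N)c2cc1OCc1ccccc1`: 58000 nM

Compound 3 stands highest of the three, well clear of the other two. Compound 4 `COc1cc2ncnc(-n3nc(-c4ccccn4)nc3N)c2cc1OCCCN(C)C` has not yet been measured. It keeps the shared core and the oxygen on the aromatic ring, and changes only what sits on the saturated chain carbon bound to that oxygen: 2-(dimethylamino)ethyl in place of phenyl on a saturated chain carbon bound to an oxygen on an aromatic ring. Read one bond further out, 3-(dimethylamino)propoxy takes the place of benzyloxy.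

Going by the values given here, no measured step makes this exact swap. The closest evidence is two steps that replace the whole group on an aromatic carbon: a 29-fold higher number from compound 1 to compound 3 (1.46 log units; beyond the scatter) and a 19-fold higher number from compound 2 to compound 3 (1.29 log units; beyond the scatter). Both are large, so a swap of this kind can move the number a long way. Yet a 1.5-fold higher number from compound 1 to compound 2 (0.18 log units; within the scatter), also on an aromatic carbon, stays within the scatter, so not every swap does. None of these steps fixes the direction for the new chain, which has no ring and holds a nitrogen. A moderate rise in this assay is a judgement, and a fall remains possible. The expected step is a 2.1-fold higher number from compound 3 to compound 4 (0.32 log units; beyond the scatter). For compound 4 the estimated value is 120000 nM, with an expected range from 30000 nM to 400000 nM.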

Compound 4, solubility: 53000 nM
Compound 4: middle estimate off by 2.3-fold (0.35 log units), on the high side; low and high end bracket the measured number.
By their numbers in this assay, from the lowest: compounds 1 and 2 (each within the scatter of the next); then compounds 4 and 3 (each within the scatter of the next).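

In this assay the swap of phenyl for 2-(dimethylamino)ethyl on a saturated chain carbon bound to an oxygen on an aromatic ring gives a 1.1-fold lower number from compound 3 to compound 4 (0.04 log units; within the scatter) and so leaves no readable difference: at this position a chain with no ring and one nitrogen stands level with the phenyl it replaces. The high numbers at this place on the shared core therefore do not depend on keeping an aromatic ring on the chain, since 3-(dimethylamino)propoxy in place of amino gives an 18-fold higher number from compound 2 to compound 4 (1.25 log units; beyond the scatter) and the same group in place of nitro gives a 27-fold higher number from compound 1 to compound 4 (1.42 log units; beyond the scatter) in steps as large as those seen with benzyloxy. Nothing available explains why these two quite different groups end up level.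

From the compounds shown here alone, what a plain propoxy group with no nitrogen would give remains open, so the part played by the dimethylamino group in compound 4 cannot be separated from that of the chain itself. Also open, going by these compounds, is how a shorter or longer chain carrying the same amine, or a chain ending in a morpholine, would fall in this assay at this place.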